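This account rests on a few compounds, and the source may have more. Where it says the series, first, only, none or still open, it means among the compounds named here.

Measured in a functional assay on the whole organism with Mus musculus as the target, in the rotarod test; on this read-out lower numbers stand for an effect already at smaller amounts and higher numbers for an effect only at larger amounts of compound:
Compound 1 `COc1cc2c(cc1OC)C(c1ccc(Br)cc1)=NNC(=O)C2`: 226 umol/kg
Compound 2 `COc1cc2c(cc1OC)C(c1ccc(Cl)cc1)=NNC(=O)C2`: 240 umol/kg

Within the data shown here, compound 2 stands level with compound 1, the only other compound measured, and the single step between them is a 1.1-fold higher number from compound 1 to compound 2 (0.03 log units; within the scatter). Compound 3 `COc1cc2c(cc1OC)C(c1cccc(N)c1)=NNC(=O)C2` has 3-aminophenyl in place of 4-chlorophenyl on a carbon with a double bond to nitrogen. Among the measured compounds shown here, the step to compound 2, a 1.1-fold higher number from compound 1 to compound 2 (0.03 log units; within the scatter), is the only guide, and it involves no amino group, so the guidance is weak. No shift beyond the scatter is therefore expected in this assay. The estimated step is a 1.2-fold lower number from compound 2 to compound 3 (0.08 log units; within the scatter). Compound 3 is expected at 200 umol/kg, within an estimated range of 80 umol/kg to 480 umol/kg.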

Compound 3, dose for half-maximal effect: 51.5 umol/kg
Estimate against measurement, compound 3: 3.9-fold (0.59 log units) above; the measured number lies below the stated range.
By their numbers in this assay, from the lowest: compound 3; then compounds 1 and 2 (each within the scatter of the next).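

In this assay the aryl group on the carbon with a double bond to nitrogen proves able to move the number beyond the scatter, which the exchange of one halogen for the other did not show. 3-Aminophenyl in place of 4-chlorophenyl gives a clear drop (a 4.7-fold lower number from compound 2 to compound 3 (0.67 log units; beyond the scatter)), and in place of 4-bromophenyl a similar one (a 4.4-fold lower number from compound 1 to compound 3 (0.64 log units; beyond the scatter)). Nothing given here accounts for this shift.

The change swaps both the substituent and its place on the ring, and these two remain unseparated. From the compounds shown here alone, whether a plain phenyl, a hydroxyl or an acetylated amine would behave likewise also stays open.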